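Replacing the pentafluorophenyl group of compound 2 with 4-bromophenyl

This account rests on a few compounds, and the source may have more. Where it says the series, first, only, none or still open, it means among the compounds named here.

Within the data shown here, in a functional assay on DU-145 cells (Homo sapiens) for inhibition, read by trypan blue exclusion, with a stated time of 96 h (a higher number here means a weaker inhibitor of growth, a lower number a stronger inhibitor of growth), compound 2 (`O=C(/C(=C\c1ccc(O)c([N+](=O)[O-])c1)SCc1ccc(Br)cc1)c1c(F)c(F)c(F)c(F)c1F`) gives 10000 nM and holds the lowest of the three numbers so far. Compound 1 (`Cc1ccc(S/C(=C/c2ccc(Br)cc2)C(=O)c2ccc(Cl)cc2)cc1`) gives 25000 nM and compound 3 (`O=C(/C(=C\c1ccc(O)c([N+](=O)[O-])c1)S(=O)(=O)Cc1ccc(Br)cc1)c1c(F)c(F)c(F)c(F)c1F`) gives 50000 nM in this assay and both lie beyond the scatter from compound 2.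

Compound 4 (`O=C(/C(=C\c1ccc(O)c([N+](=O)[O-])c1)SCc1ccc(Br)cc1)c1ccc(Br)cc1`) has not yet been measured. Among the measured compounds shown here, its single change from compound 2 is 4-bromophenyl in place of 2,3,4,5,6-pentafluorophenyl on a carbonyl carbon and the rest of the structure stays as it is.

For the measured compounds named here, only one measured step is available, and it bears on this change only indirectly. The step of a 5.0-fold higher number from compound 2 to compound 3 (0.70 log units; beyond the scatter) is modest and beyond the scatter, but it puts (4-bromobenzyl)sulfonyl in place of (4-bromobenzyl)sulfanyl and leaves the group on the carbonyl carbon untouched. Compound 1 differs from compound 2 in more than one place, so its value does not isolate the swap either. The data therefore give no direction for this change, and that modest step serves only as a rough yardstick of size. No step beyond the scatter is expected, and the expected step is a 1.3-fold lower number from compound 2 to compound 4 (0.10 log units; within the scatter) with wide uncertainty on both sides. For compound 4 the estimated value is 8000 nM with an expected range from 2500 nM to 25000 nM in this assay as the read-out.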

Compound 4, concentration for 50% growth inhibition: 10000 nM
For compound 4 the middle estimate is 1.3-fold (0.10 log units) below the measured one; low and high end bracket the measured number.
By their numbers in this assay, from the lowest: compounds 2 and 4 (each within the scatter of the next); then compounds 1 and 3 (each within the scatter of the next).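

In this assay, among these compounds, the group on the carbonyl carbon can change from 2,3,4,5,6-pentafluorophenyl to 4-bromophenyl with no change at the digits printed from compound 2 to compound 4 (within the scatter) and the number does not move, so this pair gives the first direct reading at this position. With the (4-bromobenzyl)sulfanyl group and the rest of the structure held fixed, the assay does not tell these two aromatic groups apart, whereas the change to (4-bromobenzyl)sulfonyl, a 5.0-fold higher number from compound 2 to compound 3 (0.70 log units; beyond the scatter), moves the number beyond the scatter. The compounds shown offer no measurement that could explain why the two groups on the carbonyl carbon read alike.

This single swap leaves open whether the position would tolerate a methyl group, a longer chain, or a phenyl group bearing an amine or a carboxylic acid, since both groups compared here are halogenated phenyl groups. On these data alone, it also remains open whether 4-bromophenyl and 2,3,4,5,6-pentafluorophenyl would still read alike on the (4-bromobenzyl)sulfonyl series of compound 3.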